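Dimethylamino to Acetyl on a Shared Amide-Linked Core

A few compounds are considered here, and "the series" means these few. Any claim that something is new, unique, unknown or untested is made for them only; others in the source may bear on it.

Measured compounds:
compound 1, `CCOC(=O)c1ccc2nc(NC(=O)CNC(=O)c3nn(-c4ccccc4)c(=O)c4ccccc34)sc2c1`, > 25000 nM in an assay on L cells for inhibition of Protein-serine O-palmitoleoyltransferase porcupine (Mus musculus), read by reporter gene assay, with a stated time of 24 h; a lower number here means that less compound is needed, a higher number that more compound is needed for the effect
compound 2, `CN(C)c1ccc(NC(=O)CSc2nc3c(c(=O)n2-c2ccccc2)SCC3)cc1`, > 1000 nM in this assay

Compound 1 is known in this assay only as a limit, > 25000 nM, which is the limit of > 25000 nM in this assay, at which 1 of the 2 values shown sits. Compound 2 likewise stands at a limit in this assay, > 1000 nM, namely (the limit of > 1000 nM in this assay, at which 1 of the 2 values shown sits). Going by the values given here, neither compound therefore has a number; compound 2 sits at a limit, and the one other value shown is also a limit, so no measured step between compounds exists and the spread of real values is unknown.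

Compound 3 `CC(=O)c1ccc(NC(=O)CSc2nc3c(c(=O)n2-c2ccccc2)SCC3)cc1` carries the change (acetyl in place of dimethylamino on an aromatic carbon). With compound 2 giving only a limit > 1000 nM, the step that the limit leaves unreadable from compound 2 to compound 3 is expected to be small, with no firm direction beyond the scatter. Compound 3 is estimated at 5000 nM, in a range from 1000 nM to 50000 nM, and a limit rather than a number is expected to be the likely report.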

Compound 3, half-maximal effective concentration: > 1000 nM
Compound 3: only a limit was reported; the forecaster's own chance of this, stated with the estimate: 70%; the middle value lies beyond the limit too.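

In this assay compound 3 gives only a limit, > 1000 nM. Compound 2 is likewise known only as a limit, so the step between compound 2 and compound 3 cannot be read. The compounds shown leave open how acetyl and dimethylamino compare at this place, and what real values any of them would have.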